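Swapping an ethoxy for a pyrrolidine on a shared core

The source may report more compounds than this note shows. Statements on the series, on what has been measured and on what is new or still open speak of the compounds shown alone.

For the measured compounds named here, the two compounds measured so far share one core and differ only in the side chain on an aromatic carbon. Compound 1 has the structure `CCOc1nc(N)nc2c1ncn2/C=C1/CC1(CO)CO`. In an ADME assay on Akata cells (Homo sapiens) for cytotoxicity, with a stated time of 7 days (a higher number here means that more compound is tolerated, a lower number that less compound is tolerated), compound 1 gives > 20000 nM, which is a limit of the assay rather than a number. Compound 2, with the structure `COCCOc1nc(N)nc2c1ncn2/C=C1/CC1(CO)CO`, differs by a step that the two limits leave unreadable from compound 1 to compound 2. In this assay compound 2 gives > 20000 nM, again a limit of the assay. Both values sit at the limit of > 20000 nM in this assay, at which 2 of the 2 values shown sit, so compound 1 stands at the edge of what the assay can report, and neither measured step can be read.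

Compound 3 has the structure `Nc1nc(N2CCCC2)c2ncn(/C=C3/CC3(CO)CO)c2n1`. The change from compound 1 is pyrrolidin-1-yl in place of ethoxy on an aromatic carbon. Going by the values given here, the only measured step on this core is the one from compound 1 to compound 2, and its size is not readable, so no step beyond the scatter in this assay is expected from compound 1 to compound 3. Compound 3 is therefore estimated to give about 20000 nM, within a range from 8000 nM to 50000 nM. The step this estimate means is expected to be a number no higher from compound 1 to compound 3 (the limit leaves the size open).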

Compound 3, half-maximal cytotoxic concentration: > 24000 nM
Compound 3 gave a limit, no number; the forecaster's own chance of this, stated with the estimate: 70%; middle value at least 1.2-fold (0.07 log units) away from the limit.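

In this assay compound 3 gives > 24000 nM, which is again a limit of the assay and not a number. The steps linking compound 1 and compound 2 to compound 3 therefore cannot be read. The compounds shown leave open at what concentration any of the three becomes cytotoxic, and whether the ethoxy, 2-methoxyethoxy and pyrrolidin-1-yl side chains differ at all in this assay.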